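Losing one fluoro group at the assay limit

The source may hold more compounds than are shown below. What is called first, only, known or untested is meant among the compounds shown, and "the series" means these compounds.

In an ADME assay on HEK293 cells (Homo sapiens) for cytotoxicity, with a stated time of 72 h (on this read-out lower numbers stand for an effect already at smaller amounts and higher numbers for an effect only at larger amounts of compound), three compounds have been measured:
Compound 1 `Cc1cc(NC(=O)Nc2ccccc2N)c2ccccc2n1`: > 25000 nM
Compound 2 `Cc1ccc(NC(=O)Nc2cc(C)nc3ccccc23)cc1`: > 25000 nM
Compound 3 `Cc1cc(NC(=O)Nc2ccc(F)c(F)c2)c2ccccc2n1`: > 25000 nM

Each of these entries is a limit of the assay and not a number. Compound 3 therefore has no exact position, and its limit is > 25000 nM.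

Compound 4 `Cc1cc(NC(=O)Nc2ccc(F)cc2)c2ccccc2n1` differs from compound 3 in one place: hydrogen in place of fluoro on an aromatic carbon. In words, it has hydrogen in place of fluoro on an aromatic carbon.

Among the measured compounds shown here, the only measured step between two compounds is a step that the two limits leave unreadable from compound 1 to compound 2. It involves a different change, 4-methylphenyl in place of 2-aminophenyl on an amide-type nitrogen, and it gives no size to carry over. The more useful guide is the limit of > 25000 nM in this assay, at which 3 of the 3 values shown sit. On that basis, no step beyond the scatter is expected in this assay, and the estimated step is a step that the limit leaves unreadable from compound 3 to compound 4.

Compound 4 is expected at 30000 nM, with an estimated range of 18000 nM to 60000 nM.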

Compound 4, half-maximal effective concentration: > 25000 nM
Compound 4 was reported as a limit (the forecaster's own chance of this, stated with the estimate: 85%); the middle value does not contradict the limit.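

No new step can be read for compound 4 against compound 1, compound 2 or compound 3 in this assay, as each entry is only a limit: the limit of > 25000 nM in this assay, at which 4 of the 4 values shown sit.

The compounds shown leave open whether hydrogen in place of fluoro changes cytotoxicity at all.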